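A few compounds are considered here, and "the series" means these few. Any claim that something is new, unique, unknown or untested is made for them only; others in the source may bear on it.

Compound 1 `COC1=C(OC)[C@H](O)[C@H](C/C=C(\C)CC/C=C(\C)C[C@@H]2C[C@@H](C)C(=O)O2)[C@@H](C)C1=O`, compound 2 `COC1=C(O)[C@H](O)[C@H](C/C=C(\C)CC/C=C(\C)C[C@H](O)/C=C(\C)CO)[C@@H](C)C1=O` and compound 3 `COC1=C(OC)[C@H](O)[C@H](C/C=C(\C)CC/C=C(\C)C[C@H](O)/C=C(\C)CO)[C@@H](C)C1=O` share one core and differ in their side chains and substituents. In a functional assay on PC-3 cells (Homo sapiens) for inhibition, read by sulforhodamine B assay, with a stated time of 48 h (a higher number here means a weaker inhibitor of growth, a lower number a stronger inhibitor of growth), compound 1 reaches only the limit of the assay, > 30000 nM. Compound 2 likewise gives no number in this assay but only the limit > 30000 nM. Going by the values given here, both measured values thus sit at the same boundary, as summarised in the limit of > 30000 nM in this assay, at which 2 of the 2 values shown sit, so nothing about this pair tells which of the two is the stronger or weaker inhibitor of growth, and no step between them can be drawn.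

Compound 3 arises from compound 2 by methyl in place of hydrogen on an oxygen on an unsaturated carbon; cut one bond further out, the difference reads hydroxy to methoxy. Among the compounds with values here, with no measured step on the way, the expectation for this change rests only on where compound 2 stands, and compound 2 stands at the limit. Compound 3 is therefore expected to give about 45000 nM in this assay, with a range from 15000 nM to 150000 nM, most probably reported again as a limit. The step this estimate implies, a step that the limit leaves unreadable from compound 2 to compound 3, is expected to lie within the scatter, with no direction beyond it.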

Compound 3, concentration for 50% growth inhibition: > 30000 nM
Compound 3: only a limit was reported; the forecaster's own chance of this, stated with the estimate: 80%; the middle value is on the limit's open side.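

In this assay compound 1, compound 2 and compound 3 all give only a limit, so no step from compound 1 or compound 2 to compound 3 can be read: the limit of > 30000 nM in this assay, at which 3 of the 3 values shown sit.

The compounds shown leave open how strongly any of the three inhibits growth, and whether hydroxy to methoxy or the difference in side chain changes that inhibition at all.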